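The compounds below may be only part of what the source reports. "The series", "measured", "known", "first", "only" and "open" are said of these compounds alone.

Compound 2, `COc1cc2c(Nc3ccc(C#N)cc3)ncnc2cc1OCCCN1CCC(c2ccccc2)CC1`, gives 7770 nM in a functional assay on SH-SY5Y cells (Homo sapiens) for antiproliferative activity, read by MTT assay, with a stated time of 72 h; a higher number here means a weaker inhibitor, a lower number a stronger inhibitor. Among the compounds with values here, of the two numbers measured so far, compound 2 has the lowest, and its nearest neighbour is compound 1, `COc1cc2c(Nc3ccc(C#N)cc3)ncnc2cc1OCCCN1CCC(C)CC1`, which in this assay gives 7900 nM; the step of a 1.0-fold lower number from compound 1 to compound 2 (0.01 log units; within the scatter) lies within the scatter. Compound 3, `COc1cc2c(Nc3ccc(C#N)cc3)ncnc2cc1OCCCN1CCc2ccccc2C1`, has not yet been measured. It differs from compound 2 by 1,2,3,4-tetrahydroisoquinolin-2-yl in place of 4-phenylpiperidin-1-yl on a saturated chain carbon, three bonds along the chain from an oxygen on an aromatic ring. Within the data shown here, the only measured step, from compound 1 to compound 2, also touched the saturated ring carbon of this amine, and it produced no change beyond the scatter. Fusing the aromatic ring onto the saturated ring has no measured counterpart, so the expectation rests on that single step alone. Compound 3 is therefore expected to show a step of a 1.0-fold lower number from compound 2 to compound 3 (0.02 log units; within the scatter), that is, no change beyond the scatter. The estimate for compound 3 in this assay is 7500 nM, with a range from 3000 nM to 19000 nM.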

Compound 3, half-maximal inhibitory concentration: > 100000 nM
Compound 3: no number, only a limit (the forecaster's own chance of this, stated with the estimate: 5%); at least 13-fold (1.12 log units) between middle value and limit.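

In this assay, 1,2,3,4-tetrahydroisoquinolin-2-yl in place of 4-phenylpiperidin-1-yl gives an at least 12-fold higher number from compound 2 to compound 3 (1.10 log units; beyond the scatter), and the same group in place of 4-methylpiperidin-1-yl gives an at least 12-fold higher number from compound 1 to compound 3 (1.10 log units; beyond the scatter). The result for compound 3 is a limit of the assay and not a number: the limit of > 100000 nM in this assay, at which 1 of the 3 values shown sits. The amine on this saturated chain carbon therefore matters in this assay, which the earlier step could not show: 4-methylpiperidin-1-yl and 4-phenylpiperidin-1-yl lie within the scatter of each other, while 1,2,3,4-tetrahydroisoquinolin-2-yl stands well apart from both.

With only one fused amine among the compounds shown, the full size of the step stays unknown, and so does the feature of the amine that goes with it. As far as these compounds go, whether an unsubstituted piperidine, a morpholine or a 4-benzylpiperidine would fall with compound 1 and compound 2 or with compound 3 remains open.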